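Adding a further methoxy to compound 3

This account rests on a few compounds, and the source may have more. Where it says the series, first, only, none or still open, it means among the compounds named here.

In a functional assay on MCF7 cells (Homo sapiens) for antiproliferative activity, read by sulforhodamine B assay, with a stated time of 72 h (on this read-out higher numbers stand for weaker inhibition and lower numbers for stronger inhibition), compound 3 (`COc1cc(/C=C2\CCC=CC2=O)cc(OC)c1`) gives 4620 nM and lies within the scatter of compound 2 (`COc1ccc(/C=C2\CCC=CC2=O)cc1OC`) at 5230 nM while compound 1 (`COc1cccc(/C=C2\CCC=CC2=O)c1`) gives the lowest number of the three at 2030 nM in this series. The next change leads to compound 4 (`COc1cc(/C=C2\CCC=CC2=O)cc(OC)c1OC`) and is methoxy in place of hydrogen on an aromatic carbon with methoxy in place of hydrogen on an aromatic carbon, ortho to two methoxy groups. Two measured steps make the same replacement: a 2.6-fold higher number from compound 1 to compound 2 (0.41 log units; beyond the scatter) and a 2.3-fold higher number from compound 1 to compound 3 (0.36 log units; beyond the scatter) are both modest and both upward. Neither starts from a compound carrying as many methoxy groups as compound 3, so a smaller step in the same direction is expected in this assay and not clearly one beyond the scatter. The expected step is a 1.5-fold higher number from compound 3 to compound 4 (0.18 log units; within the scatter) on this estimate. For compound 4 the estimated value is 7000 nM with an expected range from 2300 nM to 16000 nM on repeated measurement.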

Compound 4, half-maximal inhibitory concentration: 5260 nM
Beside the measured number, compound 4's estimate is 1.3-fold (0.12 log units) above it; measured number inside the range.
By their numbers in this assay, from the lowest: compound 1; then compounds 3, 2 and 4 (each within the scatter of the next).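

Placing a methoxy ortho to two methoxy groups gives a 1.1-fold higher number from compound 3 to compound 4 (0.06 log units; within the scatter) in this assay, and the same replacement on compound 2 gives a 1.0-fold higher number from compound 2 to compound 4 (0.00 log units; within the scatter); neither step lies beyond the scatter, unlike the two steps from compound 1. Even so, the new steps cannot be separated from those earlier ones: the same change on two cores in this assay, a 2.6-fold higher number (0.41 log units; beyond the scatter) from compound 1 to compound 2 and a 1.1-fold higher number (0.06 log units; within the scatter) from compound 3 to compound 4, 2.3-fold (0.35 log units) apart, within the scatter of two such steps. The second pairing reads the same: the same change on two cores in this assay, a 2.3-fold higher number (0.36 log units; beyond the scatter) from compound 1 to compound 3 and a 1.0-fold higher number (0.00 log units; within the scatter) from compound 2 to compound 4, 2.3-fold (0.35 log units) apart, within the scatter of two such steps.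

On these data alone, whether a hydroxyl, an amine or a fluorine at this position would move the number beyond the scatter remains open.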